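Replacing a bicyclic alcohol with a hydroxycyclohexyl amide substituent

A few compounds are considered here, and "the series" means these few. Any claim that something is new, unique, unknown or untested is made for them only; others in the source may bear on it.

Measured compounds:
compound 1 `CNC(=O)c1cc(C(=O)N[C@H]2CC[C@H](O)CC2)c([C@@H](C)c2cccc(Cl)c2)o1`: < 0.45 mL/min
compound 2 `CNC(=O)c1cc(C(=O)N[C@H]2[C@@H]3C[C@@H](O)C[C@@H]32)c([C@@H](C)c2ccccc2)o1`: < 0.45 mL/min

In an ADME assay on cells (Hepatocyte, Homo sapiens) for metabolic stability, read by LC-MS, with a stated time of 120 min (a higher number here means faster removal of the compound, a lower number slower removal), compound 2 gives < 0.45 mL/min, which is a limit of the assay rather than a number. Compound 1 likewise sits at a limit in this assay, as the limit of < 0.45 mL/min in this assay, at which 2 of the 2 values shown sit, shows. Compound 3 `CNC(=O)c1cc(C(=O)N[C@H]2CC[C@H](O)CC2)c([C@@H](C)c2ccccc2)o1` differs from compound 2 by a group of 7 heavy atoms (6 carbon, 1 oxygen; one six-membered non-aromatic ring of carbon only) in place of a group of 7 heavy atoms (6 carbon, 1 oxygen; one three-membered non-aromatic ring of carbon only, one five-membered non-aromatic ring of carbon only), on an amide-type nitrogen. Both measured compounds sit at the same limit, so no step beyond the scatter is expected in this assay. The expected step that the limit leaves unreadable from compound 2 to compound 3 is therefore essentially none. Compound 3 is expected to give about 0.3 mL/min, within 0.1 mL/min to 0.8 mL/min.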

Compound 3, intrinsic clearance in a liver preparation (reported as CLH), per the amount of preparation that the assay uses in the Hepatocyte assay: < 0.5 mL/min
Compound 3 was reported as a limit; the forecaster's own chance of this, stated with the estimate: 75%; the middle value lies beyond the limit too.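

In a physicochemical assay for solubility (on this read-out lower numbers stand for lower solubility and higher numbers for higher solubility), compound 2 gives >= 172 ug/mL which is a limit of the assay. In the physicochemical assay compound 3 gives >= 184 ug/mL which is also a limit. Among these compounds, compound 1, compound 2 and compound 3 all sit at limits in the Hepatocyte assay as well, so no step between these compounds can be read in either assay. On these data alone, the actual rate of removal of all three compounds and the actual solubility of compound 2 and compound 3 remain open.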